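This account rests on a few compounds, and the source may have more. Where it says the series, first, only, none or still open, it means among the compounds named here.

Measured so far:
compound 1 `Cc1ccnc(/C(N)=N/NC(=S)N2CCSCC2)c1`: 40.4%
compound 2 `Cc1cccc(/C(N)=N/NC(=S)N2CCCCC2)n1`: 68.9%

Within the data shown here, compound 2 stands highest of the two numbers in a functional assay on HeLa cells (Homo sapiens) for cytotoxicity, read by MTT assay, with a stated time of 72 h, tested at 3 uM; on this read-out lower numbers stand for less inhibition of growth and higher numbers for more inhibition of growth at the one concentration tested; compound 1 lies well below it, beyond the usual scatter, so ring size of the cyclic amine on the thiocarbonyl carbon and the substitution of the pyridine core are both open questions, with no single-change pair to separate them.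

Compound 3 `Cc1cccc(/C(N)=N/NC(=S)N2CCCC2)n1` carries pyrrolidin-1-yl in place of piperidin-1-yl on a thiocarbonyl carbon. Among the measured compounds shown here, no measured pair shows this kind of change, so its size is unknown. The expected step from compound 2 to compound 3 is a number 6.9 percentage points lower from compound 2 to compound 3 (within the scatter), a small change, within the scatter. Compound 3 is estimated at 62%, between 45% and 78%.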

Compound 3, percent growth inhibition at one concentration: 56.8%
Compound 3: the middle estimate sits 5.2 percentage points above what was measured, and the stated range covers the measured number.
By their numbers in this assay, from the lowest: compound 1; then compound 3; then compound 2.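

In this assay, the ring on the thiocarbonyl carbon now has its first single-change comparison, a number 12.1 percentage points lower from compound 2 to compound 3 (beyond the scatter), so pyrrolidin-1-yl and piperidin-1-yl are not interchangeable here. The step is modest, and this position still accepts the smaller ring with the shared core unchanged. No available data account for the step. As far as these compounds go, whether dimethylamino or azepan-1-yl at this position would give a higher or lower number remains open. Compound 1 differs from compound 2 in more than one place, so its relation to this step remains unresolved.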